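From 4-bromobenzyl to 3-methoxybenzyl, with only limits so far

The compounds below may be only part of what the source reports. "The series", "measured", "known", "first", "only" and "open" are said of these compounds alone.

Measured in a functional assay on MCF cells (Homo sapiens) for antiproliferative activity, with a stated time of 72 h; a lower number here means a stronger inhibitor, a higher number a weaker inhibitor:
Compound 1 `OC[C@H]1O[C@@H](n2cnc3c(NCc4ccccc4F)ncnc32)[C@H](O)[C@@H]1O` gives > 166000 nM
Compound 2 `OC[C@H]1O[C@@H](n2cnc3c(NCc4ccccc4Br)ncnc32)[C@H](O)[C@@H]1O` gives > 166000 nM
Compound 3 `OC[C@H]1O[C@@H](n2cnc3c(NCc4ccc(Br)cc4)ncnc32)[C@H](O)[C@@H]1O` gives > 166000 nM

Compound 3 has no number, only the limit > 166000 nM of the assay. It shares this position with the other two compounds, as the record shows: the limit of > 166000 nM in this assay, at which 3 of the 3 values shown sit. Compound 4 `COc1cccc(CNc2ncnc3c2ncn3[C@@H]2O[C@H](CO)[C@@H](O)[C@H]2O)c1` carries 3-methoxyphenyl in place of 4-bromophenyl on a saturated chain carbon bound to a nitrogen on an aromatic ring. The measured steps that bear on this are a step that the two limits leave unreadable from compound 1 to compound 3 and a step that the two limits leave unreadable from compound 2 to compound 3, along with a step that the two limits leave unreadable from compound 1 to compound 2, so none offers a size to carry over. Within the data shown here, no step of readable size or direction is therefore expected in this assay, and another limit is the likeliest result. The step expected is a step that the limit leaves unreadable from compound 3 to compound 4. The estimate for compound 4 is 170000 nM, with an expected range from 80000 nM to 350000 nM.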

Compound 4, half-maximal inhibitory concentration: > 166000 nM
Compound 4 ended at the assay's limit; the forecaster's own chance of this, stated with the estimate: 80%; the middle value lies beyond the limit too.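

Compound 4 gives > 166000 nM, which is a limit and not a number: the limit of > 166000 nM in this assay, at which 4 of the 4 values shown sit. Its steps from compound 1, compound 2 and compound 3 therefore cannot be read. With no number among them, these compounds leave open whether their benzyl groups differ in activity at all.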